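Swapping a methylamino ring for a methoxy ring

This account rests on a few compounds, and the source may have more. Where it says the series, first, only, none or still open, it means among the compounds named here.

Compound 1 `CCOc1ccccc1-c1ccc(-c2nc3cnccc3c(NC(COC)C(N)=O)c2C#N)cc1`: 2.8
Compound 2 `CC[C@@H](Nc1c(C#N)c(-c2ccc(-c3ccccc3NC)cc2)nc2cnccc12)C(N)=O`: 2.5

Of the compounds shown here, two have been measured in a physicochemical assay for lipophilicity, read by HPLC, at pH 7.5; a higher number here means a more lipophilic compound, a lower number a more polar compound. Compound 1 gives 2.8, and compound 2 gives 2.5; these two values lie within the usual scatter of each other, so neither stands apart. Compound 3 `CC[C@@H](Nc1c(C#N)c(-c2ccc(-c3ccc(OC)cc3)cc2)nc2cnccc12)C(N)=O` is the next to be measured. It differs from compound 2 in one place: 4-methoxyphenyl in place of 2-(methylamino)phenyl on an aromatic carbon. Within the data shown here, no pair of measured compounds shows this kind of change, so there is no step to lean on. A small rise in this assay is expected, with the step from compound 2 to compound 3 estimated at a number 0.30 log units higher from compound 2 to compound 3 (within the scatter). Compound 3 is therefore expected to give about 2.8, in the range 2.4 to 3.2.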

Compound 3, distribution coefficient: 2.7
Compound 3: middle estimate off by 0.10 log units, on the high side; low and high end bracket the measured number.
By their numbers in this assay, from the lowest: compounds 2, 3 and 1 (each within the scatter of the next).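

In this assay, among these compounds, 4-methoxyphenyl in place of 2-(methylamino)phenyl gives a number 0.20 log units higher from compound 2 to compound 3 (within the scatter) and is the first step read at this aromatic carbon. This one change takes away the hydrogen-bond donor counted on the leaving group, and the step stays within the scatter. Nothing measured here speaks to the reason for this result. The compounds shown leave open whether an amine or a carboxylic acid on this ring, or a longer chain in place of the methoxy group, would give a step beyond the scatter.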